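This account rests on a few compounds, and the source may have more. Where it says the series, first, only, none or still open, it means among the compounds named here.

Compounds measured so far:
compound 1 `CC1(C)Cc2c(sc(NC(=O)c3cccnc3O)c2C(N)=O)C(C)(C)O1`, 190 nM
compound 2 `CC1(C)Cc2c(sc(NC(=O)c3nnc[nH]3)c2C(N)=O)C(C)(C)O1`, 467 nM
compound 3 `CC1(C)Cc2c(sc(NC(=O)C(C)(C)O)c2C(N)=O)C(C)(C)O1`, 16 nM

In an assay on cells for positive allosteric modulation of Cystic fibrosis transmembrane conductance regulator variant F508del (Homo sapiens), with stated times of 10 min and 7 s, in the presence of a further agent that is not named here (a higher number here means that more compound is needed for the effect, a lower number that less compound is needed), compound 3 gives the lowest number of the three: the step of a 12-fold lower number from compound 1 to compound 3 (1.07 log units; beyond the scatter) and the step of a 29-fold lower number from compound 2 to compound 3 (1.47 log units; beyond the scatter) are both large and both beyond the scatter. Compound 4 `CC1(C)Cc2c(sc(NC(=O)C3(CO)CC3)c2C(N)=O)C(C)(C)O1` differs from compound 3 in one place: 1-(hydroxymethyl)cyclopropyl in place of 1-hydroxy-1-methylethyl on a carbonyl carbon. Among the measured compounds shown here, no measured step exchanges one hydroxy-bearing non-aromatic group for another, so the measured steps do not speak directly to this change; they show only that the non-ring group of compound 3 gave a far lower number than either ring-bearing group in compound 1 or compound 2. For compound 4 a step of a 1.6-fold higher number from compound 3 to compound 4 (0.19 log units; within the scatter) is therefore expected, within the scatter, and the estimate is 25 nM with a range from 8 nM to 80 nM.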

Compound 4, half-maximal effective concentration: 15 nM
Estimate against measurement, compound 4: 1.7-fold (0.22 log units) above; the measured number falls inside the stated range.
By their numbers in this assay, from the lowest: compounds 4 and 3 (each within the scatter of the next); then compound 1; then compound 2.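

Among the compounds shown here, the step of a 1.1-fold lower number from compound 3 to compound 4 (0.03 log units; within the scatter) shows that, on this carbonyl carbon, 1-(hydroxymethyl)cyclopropyl serves as well as 1-hydroxy-1-methylethyl, so a low number does not depend on the one group in compound 3. The steps of a 31-fold lower number from compound 2 to compound 4 (1.49 log units; beyond the scatter) and a 13-fold lower number from compound 1 to compound 4 (1.10 log units; beyond the scatter) show that this second hydroxy-bearing group also stays far ahead of 4H-1,2,4-triazol-3-yl and 2-hydroxypyridin-3-yl. Nothing measured here explains these steps.

Still open, going by these compounds, is what an amine or a carboxylic acid would do in place of the hydroxy group on these side groups. A longer chain carrying the hydroxy group also remains untested among the compounds shown.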